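From Fluoro to Nitro in a Level Series

The compounds below may be only part of what the source reports. "The series", "measured", "known", "first", "only" and "open" are said of these compounds alone.

In a functional assay on DU-145 cells (Homo sapiens) for cytotoxicity, read by trypan blue exclusion, with a stated time of 96 h (on this read-out higher numbers stand for weaker inhibition and lower numbers for stronger inhibition), compound 1 (`O=S(=O)(/C=C/c1ccccc1)Nc1ccccc1`) gives 10000 nM, compound 2 (`COc1cc(OC)c(/C=C/S(=O)(=O)Nc2ccc(F)c(N)c2)c(OC)c1`) gives 10000 nM and compound 3 (`COc1ccc(NS(=O)(=O)/C=C/c2c(F)c(F)c(F)c(F)c2F)cc1F`) gives 10000 nM. Compound 3 therefore stands level with the other two, despite their different substituents. Compound 4 (`COc1ccc(NS(=O)(=O)/C=C/c2c(F)c(F)c(F)c(F)c2F)cc1[N+](=O)[O-]`) keeps the structure of compound 3 except for one change: nitro in place of fluoro on an aromatic carbon, ortho to a methoxy group (nitro in place of fluoro on an aromatic carbon). Among the measured compounds shown here, no measured pair shows what such a swap does, so the only guide is compound 3 at 10000 nM. The expected step of a 1.4-fold lower number from compound 3 to compound 4 (0.15 log units; within the scatter) is none beyond the scatter. Compound 4 is estimated at 7000 nM, with an expected range of 1500 nM to 15000 nM.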

Compound 4, half-maximal inhibitory concentration: 100000 nM
Beside the measured number, compound 4's estimate is 14-fold (1.15 log units) below it, outside the stated range (above it).
By their numbers in this assay, from the lowest: compounds 1, 2 and 3 (each within the scatter of the next); then compound 4.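

In this assay, nitro in place of fluoro on this aromatic carbon, ortho to a methoxy group, gives a 10-fold higher number from compound 3 to compound 4 (1.00 log units; beyond the scatter), which stands for weaker inhibition. Compounds 1, 2 and 3 sit level, so they gave no sign that the read-out could respond to any change. This swap shows that it can, and that the change here goes towards weaker inhibition. On these data alone, whether a nitrile or a carboxylic acid on this carbon would stay level with compound 3 or move as nitro does remains open. No supporting measurement is available to explain the step.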